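The source may report more compounds than this note shows. Statements on the series, on what has been measured and on what is new or still open speak of the compounds shown alone.

Within the data shown here, in a functional assay on CHO cells for agonist activity at prostaglandin E2 receptor EP4 subtype (Rattus norvegicus), read by cAMP accumulation and immunoassay, with a stated time of 10 min (a higher number here means that more compound is needed for the effect, a lower number that less compound is needed), compound 2 `CCc1cccc(C[C@H](O)/C=C/[C@H]2CSC(=O)N2CCSCCCC(=O)O)c1` gives 1.9 nM, the lowest of the two numbers so far; its nearest neighbour is compound 1 `O=C(O)CCCSCCN1C(=O)SC[C@@H]1/C=C/[C@@H](O)Cc1ccccc1`, which gives 4.8 nM. Among the measured compounds shown here, the one measured step, a 2.5-fold lower number from compound 1 to compound 2 (0.40 log units; beyond the scatter), turned on ethyl in place of hydrogen on an aromatic carbon. Compound 3 `O=C(O)CCCSCCN1C(=O)SC[C@@H]1/C=C/[C@@H](O)Cc1cccc(C(F)(F)F)c1` carries trifluoromethyl in place of ethyl on an aromatic carbon. For the measured compounds named here, no measured step covers this exchange; the earlier step shows only that a group at this carbon is tolerated, so no step beyond the scatter is expected in this assay, a 1.1-fold higher number from compound 2 to compound 3 (0.02 log units; within the scatter). Compound 3 is therefore estimated at 2 nM, between 0.6 nM and 7 nM.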

Compound 3, half-maximal effective concentration: 4.3 nM
Compound 3: middle estimate off by 2.2-fold (0.33 log units), on the low side; low and high end bracket the measured number.
By their numbers in this assay, from the lowest: compound 2; then compounds 3 and 1 (each within the scatter of the next).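

In this assay the choice of group at this aromatic carbon matters: replacing ethyl with trifluoromethyl gives a 2.3-fold higher number from compound 2 to compound 3 (0.35 log units; beyond the scatter). Trifluoromethyl and hydrogen at this carbon cannot be told apart, with a 1.1-fold lower number from compound 1 to compound 3 (0.05 log units; within the scatter), so the lower number seen with ethyl does not extend to every group placed here. No evidence is available that bears on why the two groups differ. The compounds shown leave open how a methoxy group, a chlorine atom or a longer chain such as propyl would read at this carbon.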